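Compound 2 to compound 4: methyl for chloro

The source may hold more compounds than are shown below. What is called first, only, known or untested is meant among the compounds shown, and "the series" means these compounds.

In a functional assay on HCT-116 cells (Homo sapiens) for inhibition, read by CCK-8 assay, with a stated time of 72 h, tested at 2 uM (on this read-out lower numbers stand for less inhibition of growth and higher numbers for more inhibition of growth at the one concentration tested), compound 2 (`Nc1ccccc1NC(=O)/C=C/c1ccc(CSc2ccc(Cl)cc2)cc1`) gives 5.62% and stands within the scatter of both other measured compounds. Compound 1 (`COc1ccc(SCc2ccc(/C=C/C(=O)Nc3ccccc3N)cc2)cc1OC`) gives 12.9% on the same read-out, and compound 3 (`Nc1ccccc1NC(=O)c1ccc(CSc2cccc(F)c2)cc1`) gives 5.5% there, so no order can be drawn among the three numbers.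

Compound 4 (`Cc1ccc(SCc2ccc(/C=C/C(=O)Nc3ccccc3N)cc2)cc1`) is reached from compound 2 by a single exchange, methyl in place of chloro on an aromatic carbon with methyl in place of chloro on an aromatic carbon, para to a large group. Among the measured compounds shown here, one measured step bears on it, namely a number 7.3 percentage points lower from compound 1 to compound 2 (within the scatter) with 4-chlorophenyl in place of 3,4-dimethoxyphenyl on a sulfur. That step replaces more of the structure than the present exchange and still stays within the scatter, so no step beyond the scatter is expected in this assay here, and no direction can be relied on.

The expected step is a number 2.4 percentage points higher from compound 2 to compound 4 (within the scatter) and remains within the scatter. For compound 4 the estimated value is 8% with an expected range from 0% to 18% on this read-out.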

Compound 4, percent growth inhibition at one concentration: 6.23%
Compound 4: middle estimate off by 1.8 percentage points, on the high side; low and high end bracket the measured number.
By their numbers in this assay, from the lowest: compounds 3, 2, 4 and 1 (each within the scatter of the next).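

In this assay, among the compounds shown here, the exchange of chloro for methyl on the aromatic carbon para to a large group gives a number 0.6 percentage points higher from compound 2 to compound 4 (within the scatter) and so adds a first direct pair at this position, one in which the two groups cannot be told apart. The wider exchange on the sulfur, 4-methylphenyl in place of 3,4-dimethoxyphenyl, gives a number 6.7 percentage points lower from compound 1 to compound 4 (within the scatter) and therefore also allows no ranking of these aryl groups in this read-out. No measured information is available to explain these results.

From the compounds shown here alone, whether an amine or a carboxylic acid on this aromatic carbon, or a longer chain in place of methyl, would give a step beyond the scatter remains open. Going by these compounds, it is also open whether the chloro and methyl compounds would separate at any other concentration.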